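This account rests on a few compounds, and the source may have more. Where it says the series, first, only, none or still open, it means among the compounds named here.

Compound 1, `COc1ccc(-c2ccn(CCC(C)C)c(=O)c2C#N)cc1F`, and compound 2, `COc1ccc(-c2ccn(CCC(C)C)c(=O)c2C#N)cc1Cl`, share one core and differ in a single place. In a functional assay on CHO cells for positive allosteric modulation of metabotropic glutamate receptor 2 (Homo sapiens), read by scintillation counting and GTPgammaS binding, with a stated time of 30 min (on this read-out higher numbers stand for an effect only at larger amounts of compound and lower numbers for an effect already at smaller amounts), compound 2 gives 363 nM, and compound 1 gives 1170 nM. The change between them, (fluoro in place of chloro on an aromatic carbon), produced a 3.2-fold higher number from compound 2 to compound 1 (0.51 log units; beyond the scatter).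

Compound 3, `CCCCn1ccc(-c2ccc(Oc3ccnc(C)c3)c(Cl)c2)c(C#N)c1=O`, carries a larger group on the same aromatic ring; the difference between its core and the core of compound 2 is not broken down here. In this assay compound 3 gives 166 nM, the lowest of the three numbers seen so far.

Compound 4, `CCCCn1ccc(-c2ccc(Oc3ccnc(C)c3)c(F)c2)c(C#N)c1=O`, has not yet been measured. It differs from compound 3 by fluoro in place of chloro on an aromatic carbon. Going by the values given here, this is the same kind of change as the one from compound 2 to compound 1, though the place differs: there the fluoro stands ortho to a methoxy group, here ortho to a (2-methylpyridin-4-yl)oxy group. Resting on the step of a 3.2-fold higher number from compound 2 to compound 1 (0.51 log units; beyond the scatter), the expectation for compound 4 is a 3.0-fold higher number from compound 3 to compound 4 (0.48 log units; beyond the scatter). Compound 4 is therefore estimated at 500 nM, with a range from 200 nM to 1300 nM.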

Compound 4, half-maximal effective concentration: 316 nM
Compound 4: the middle estimate sits 1.6-fold (0.20 log units) above what was measured; measured number inside the range.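

On the core of compound 3, fluoro in place of chloro on an aromatic carbon gives a 1.9-fold higher number from compound 3 to compound 4 (0.28 log units; within the scatter), so in this assay this step alone does not separate the two compounds. Set beside the step on the other core, it does not stand apart from it: the same change on two cores in this assay, a 3.2-fold higher number (0.51 log units; beyond the scatter) from compound 2 to compound 1 and a 1.9-fold higher number (0.28 log units; within the scatter) from compound 3 to compound 4, 1.7-fold (0.23 log units) apart, within the scatter of two such steps Within these two pairs, then, the change carries from one core to the other without a step that can be told from the earlier one, but two pairs cannot show that it would do so on any further core, and they do not show why the first step lies beyond the scatter while the second lies within it.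

The compounds shown leave open how a bromo or a trifluoromethyl group would compare with chloro and fluoro at this place on either core. They also leave open whether the step would stay the same with a longer chain in place of the butyl chain of compound 3.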